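Series notes: two-ring hydrazide pair, change on the benzoyl side

The source may hold more compounds than are shown below. What is called first, only, known or untested is meant among the compounds shown, and "the series" means these compounds.

The series is read in an assay on cells for agonist activity at ecdysone receptor (Bombyx mori), read by a luciferase reporter, with a stated time of 24 h; a higher number here means that more compound is needed for the effect, a lower number that less compound is needed. Going by the values given here, compound 1 `CC(C)(C)N(NC(=O)c1ccccc1)C(=O)c1ccccc1C(F)(F)F` gives 631 nM, and compound 2 `CCc1ccccc1C(=O)N(NC(=O)c1ccccc1)C(C)(C)C` gives 589 nM; the single one-place step recorded, a 1.1-fold lower number from compound 1 to compound 2 (0.03 log units; within the scatter), is ethyl in place of trifluoromethyl on an aromatic carbon and lies within the scatter. Compound 3 `CC(C)(C)N(NC(=O)c1ccccc1I)C(=O)c1ccccc1Cl` gives 1290 nM, the highest of the three numbers; the nearest of the others is compound 1, with a gap beyond the scatter, and compound 2 lies furthest, also beyond the scatter. Among the compounds with values here, compound 3 differs from compounds 1 and 2 in more than one place, so no single step is drawn to it.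

Compound 4 `CC(C)(C)N(NC(=O)c1ccc(Br)cc1)C(=O)c1ccccc1Cl` is the next member. Its change from compound 3 is 4-bromophenyl in place of 2-iodophenyl on a carbonyl carbon, on the carbonyl carbon whose other neighbour is the amide-type nitrogen. Within the data shown here, no measured step touches this position: the only recorded step, a 1.1-fold lower number from compound 1 to compound 2 (0.03 log units; within the scatter), sits on the other aromatic ring and says nothing about a change at the carbonyl side. The expectation therefore rests on the spread of the three numbers alone, with wide uncertainty and no direction claimed beyond the scatter; for compound 4 the expected step is a 1.6-fold lower number from compound 3 to compound 4 (0.21 log units; within the scatter). Compound 4 is estimated at 800 nM, within 300 nM to 2200 nM.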

Compound 4, half-maximal effective concentration: 33.9 nM
Beside the measured number, compound 4's estimate is 24-fold (1.37 log units) above it, and the stated range ends above it.
By their numbers in this assay, from the lowest: compound 4; then compounds 2 and 1 (each within the scatter of the next); then compound 3.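

In this assay, going by these compounds alone, the carbonyl carbon whose other neighbour is the amide-type nitrogen proves a sensitive place: 4-bromophenyl in place of 2-iodophenyl gives a 38-fold lower number from compound 3 to compound 4 (1.58 log units; beyond the scatter), whereas the only earlier one-place step, a 1.1-fold lower number from compound 1 to compound 2 (0.03 log units; within the scatter), stayed within the scatter and did not touch this place. The two groups match in heavy-atom count, in their single six-membered aromatic ring of carbon, in hydrogen-bond donor and acceptor counts, and in net charge, so these counts do not follow the large step; what differs is the halogen and where the name places it on the ring. The data at hand offer no measurement that bears on why this change carries so large a step.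

The step changes the halogen and its ring position together, so the compounds shown cannot separate the two; 2-bromophenyl and 4-iodophenyl would be needed for that. Also open, on these data alone, is how this place responds to a group other than a halogen on the ring, such as a 4-aminophenyl or a 4-carboxyphenyl group, and whether the step holds with a different group on the other benzoyl ring.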